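This account rests on a few compounds, and the source may have more. Where it says the series, first, only, none or still open, it means among the compounds named here.

Measured compounds:
- compound 1 `CC(C)[C@H](NC(=O)CN(c1ncnc2c1ncn2C1CCCCO1)C1CC1)C(=O)OCc1ccccc1`: in a functional assay on the whole organism (Tail, strain ICR) with Mus musculus as the target, in the tail flick test, with a stated time of 120 min, at a dose of 25 umol/kg by the oral route (a higher number here means a stronger effect of the compound at the dose given, a lower number a weaker effect), compound 1 gives 25.8%
- compound 2 `CC[C@H](C)[C@H](NC(=O)CN(c1ncnc2c1ncn2C1CCCCO1)C1CC1)C(=O)OCc1ccccc1`: compound 2 gives 20.4%
- compound 3 `NC(=O)CC[C@H](NC(=O)CN(c1nc(Cl)nc2[nH]cnc12)C1CC1)C(=O)O`: compound 3 gives 17.8%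

Compound 2 holds the second highest of the three numbers in this assay; its nearest neighbour is compound 3, its furthest compound 1, and both gaps lie within the scatter, so no order among the three is claimed.

Compound 4 `O=C(CN(c1ncnc2c1ncn2C1CCCCO1)C1CC1)N[C@@H](CCC(=O)OCc1ccccc1)C(=O)OCc1ccccc1` is to be measured in this assay. It differs from compound 2 by 2-(benzyloxycarbonyl)ethyl in place of sec-butyl on a saturated chain carbon bound to an amide-type nitrogen and a carbonyl carbon.

Among the compounds with values here, the only measured step that bears on it is a number 5.4 percentage points lower from compound 1 to compound 2 (within the scatter), a change at a different chain carbon and within the scatter. Within the data shown here, no measured step exchanges sec-butyl for a chain carrying an ester and an aromatic ring, so the read-across is weak. The expectation is that a number 0.4 percentage points lower from compound 2 to compound 4 (within the scatter) stays within the scatter. Compound 4 is estimated at 20%, with a range from 8% to 32%.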

Compound 4, a percentage reported as activity, at one dose (the size of the read-out at that dose, not a potency): 20.7%
For compound 4 the middle estimate is 0.7 percentage points below the measured one, within the range that was stated.
By their numbers in this assay, from the lowest: compounds 3, 2, 4 and 1 (each within the scatter of the next).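

In this assay the exchange gives a number 0.3 percentage points higher from compound 2 to compound 4 (within the scatter) and also a number 5.1 percentage points lower from compound 1 to compound 4 (within the scatter) as its second reading. The earlier compounds shown here carried only isopropyl or sec-butyl on the saturated chain carbon bound to an amide-type nitrogen and a carbonyl carbon, whereas 2-(benzyloxycarbonyl)ethyl, with its aromatic ring and 12 heavy atoms, leaves the read-out within the scatter of both. No supporting data on hand account for this result.

Still open, on these data alone, is whether a primary amine or an unbranched hexyl chain at this place would also stay within that scatter.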